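This account rests on a few compounds, and the source may have more. Where it says the series, first, only, none or still open, it means among the compounds named here.

Three compounds from one series were measured in an assay on isolated protein for agonist activity at Bile acid receptor (Homo sapiens), read by FRET; on this read-out higher numbers stand for an effect only at larger amounts of compound and lower numbers for an effect already at smaller amounts. Compound 1 `CC(C)c1onc(-c2c(Cl)cccc2Cl)c1COc1ccc(N(C)C(=O)c2ccc(C(=O)O)cc2)c(C(F)(F)F)n1` gives 235 nM in this assay. Compound 2 `CC(C)c1onc(-c2c(Cl)cccc2Cl)c1COc1ccc(NC(=O)c2ccc(C(=O)O)cc2)c(C(F)(F)F)n1` carries an amide hydrogen where compound 1 carries a methyl; in this assay compound 2 gives 452 nM. The step of a 1.9-fold lower number from compound 2 to compound 1 (0.28 log units; within the scatter) is the change (methyl in place of hydrogen on an amide-type nitrogen). Since that step stays within the scatter, the two values cannot be placed in an order. Compound 3 `CC(Nc1ccc(C(=O)O)cc1)c1ccc(OCc2c(-c3c(Cl)cccc3Cl)noc2C2CC2)nc1C(F)(F)F` gives 101 nM in this assay, the lowest of the three numbers, and its distance to compound 1 as well as to compound 2 lies beyond the scatter. The difference between the core of compound 3 and the core of compound 2 is not broken down here.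

Compound 4 `CC(c1ccc(OCc2c(-c3c(Cl)cccc3Cl)noc2C2CC2)nc1C(F)(F)F)N(C)c1ccc(C(=O)O)cc1` has not been measured in this assay. It differs from compound 3 by methyl in place of hydrogen on a nitrogen on an aromatic ring. Among the measured compounds shown here, this is the same kind of change as the one from compound 2 to compound 1, but not the same: in the earlier pair the nitrogen is amide-type, with an aromatic carbon and a carbonyl carbon as its other neighbours, whereas in compound 3 the nitrogen sits on an aromatic ring with an aromatic carbon and a saturated chain carbon as its other neighbours. For compound 4 a step of about a 1.3-fold lower number from compound 3 to compound 4 (0.10 log units; within the scatter) is expected in this assay, resting on the earlier pair, because a 1.9-fold lower number from compound 2 to compound 1 (0.28 log units; within the scatter) was small and within the scatter, and on the different surroundings of the nitrogen, which leave the direction uncertain. Compound 4 is therefore estimated to give around 80 nM in this assay, with a plausible range from 30 nM to 250 nM.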

Compound 4, half-maximal effective concentration: 179 nM
Estimate against measurement, compound 4: 2.2-fold (0.35 log units) below; the measured number falls inside the stated range.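

Read in this assay, the new pair gives a 1.8-fold higher number from compound 3 to compound 4 (0.25 log units; within the scatter), for methyl in place of hydrogen on a nitrogen on an aromatic ring, so compound 3 and compound 4 cannot be placed in an order. Taken singly, neither this step nor the earlier one on the amide-type nitrogen separates its two compounds, yet the two steps set side by side do differ: the same change on two cores in this assay, a 1.9-fold lower number (0.28 log units; within the scatter) from compound 2 to compound 1 and a 1.8-fold higher number (0.25 log units; within the scatter) from compound 3 to compound 4, 3.4-fold (0.53 log units) apart, beyond the scatter of two such steps This shows that the size and direction of the step found on one core could not simply be carried over to the other, but it does not show what sets them apart, since the two pairs differ both in the surroundings of the nitrogen and in the rest of the core, and each kind of nitrogen is represented by one pair only.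

The compounds shown leave open whether the gap follows the kind of nitrogen or the rest of the core, which would take the same change on an amide-type nitrogen within the core of compound 3. They also leave open how an ethyl or an acetyl group on this nitrogen would read in this assay.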